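Working notes: imidazolyl to dimethylamino swap on two cores

The compounds below may be only part of what the source reports. "The series", "measured", "known", "first", "only" and "open" are said of these compounds alone.

Measured compounds:
compound 1, `COC(=O)N(C)C(C)C#CCn1ccnc1`: 6.6 mg/kg
compound 2, `COC(=O)N(C)C(C)C#CCN(C)C`: 11.8 mg/kg
compound 3, `O=C1NCCN1CC#CCn1ccnc1`: > 100 mg/kg

Compound 1 and compound 2 share a core and differ in one place, (dimethylamino in place of 1H-imidazol-1-yl on a saturated chain carbon bound to a triple-bonded carbon). In a functional assay on the whole organism for agonist activity, with Mus musculus as the target (on this read-out lower numbers stand for an effect already at smaller amounts and higher numbers for an effect only at larger amounts of compound), compound 1 gives 6.6 mg/kg and compound 2 gives 11.8 mg/kg; the step is a 1.8-fold higher number from compound 1 to compound 2 (0.25 log units; within the scatter), so the two values are not told apart by this assay.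

Compound 3 carries a different core. In this assay compound 3 gives only a limit, > 100 mg/kg, which is a limit of the assay and not a number; (the limit of > 100 mg/kg in this assay, at which 1 of the 3 values shown sits). The difference between the core of compound 3 and the core of compound 1 is not broken down here.

Compound 4, `CN(C)CC#CCN1CCNC1=O`, is not yet measured in this assay. It stands to compound 3 as compound 2 stands to compound 1: dimethylamino in place of 1H-imidazol-1-yl on a saturated chain carbon bound to a triple-bonded carbon. The two changes are of the same kind, made at the same place on the chain.

For compound 4 the expected step is a step that the limit leaves unreadable from compound 3 to compound 4. That expectation rests on the measured step of a 1.8-fold higher number from compound 1 to compound 2 (0.25 log units; within the scatter), which was within the scatter, and on compound 3 standing at a limit in this assay. Compound 4 is therefore expected to give about 150 mg/kg in this assay, most likely again reported as a limit. The expected range for compound 4 runs from 50 mg/kg to 450 mg/kg.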

Compound 4, dose for half-maximal effect: 9.7 mg/kg
Estimate against measurement, compound 4: 15-fold (1.19 log units) above; the measured number lies below the stated range.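

Series notes on the swap of 1H-imidazol-1-yl for dimethylamino on a saturated chain carbon bound to a triple-bonded carbon: in this assay the change gives an at least 10-fold lower number from compound 3 to compound 4 (1.01 log units; beyond the scatter), so it does not carry over from one core to the other with the same size, as the two steps set side by side show: the same change on two cores in this assay, a 1.8-fold higher number (0.25 log units; within the scatter) from compound 1 to compound 2 and an at least 10-fold lower number (1.01 log units; beyond the scatter) from compound 3 to compound 4, at least 18-fold (1.26 log units) apart, beyond the scatter of two such steps. Compound 3 gives > 100 mg/kg, which is a limit of the assay and not a number, so the step to compound 4 has a known least size but no known full size: the limit of > 100 mg/kg in this assay, at which 1 of the 4 values shown sits. The result shows that the outcome of this change depends on the core in these two pairs, but it does not show what in either core is responsible, and two pairs set no rule for the series.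

Still open, on these data alone, is whether another amine, such as diethylamino, on a saturated chain carbon bound to a triple-bonded carbon would follow dimethylamino on both cores or only on one. Also open, as far as these compounds go, is whether a longer chain in place of the present one would keep the difference between the two cores or remove it.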